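Removing the Chain Methyl from Compound 3

The source may hold more compounds than are shown below. What is called first, only, known or untested is meant among the compounds shown, and "the series" means these compounds.

- compound 1 `Cc1cc(CCC(=O)O)ccc1-c1noc(-c2ccc(OC(C)C)c(C#N)c2)n1`: 0.1 mg/kg
- compound 2 `Cc1cc(C(C)CC(=O)O)ccc1-c1noc(-c2ccc(OC(C)C)c(C(F)(F)F)c2)n1`: 0.1 mg/kg
- compound 3 `Cc1cc(CC(C)C(=O)O)ccc1-c1noc(-c2ccc(OC(C)C)c(C(F)(F)F)c2)n1`: 0.1 mg/kg

All three values come from a functional assay on the whole organism with Mus musculus as the target; on this read-out higher numbers stand for an effect only at larger amounts of compound and lower numbers for an effect already at smaller amounts. There, compound 3 stands level with compound 1 and compound 2 at the digits shown, so these numbers set no order among the three.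

The next compound to be tested is compound 4 `Cc1cc(CCC(=O)O)ccc1-c1noc(-c2ccc(OC(C)C)c(C(F)(F)F)c2)n1`. Its difference from compound 3 is hydrogen in place of methyl on a saturated chain carbon bound to a carbonyl carbon and a saturated chain carbon. In words, this is hydrogen in place of methyl on a saturated chain carbon bound to a carbonyl carbon and a saturated chain carbon, which turns 2-carboxypropyl into 2-carboxyethyl.

Going by the values given here, one measured step bears directly on this chain: no change at the digits printed from compound 2 to compound 3 (within the scatter). That step replaces one methyl-bearing form of the chain with another and stays within the scatter of repeated measurements. Among the compounds with values here, no measured step shows the methyl being removed outright, so this evidence is indirect.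

In this assay, no shift beyond the scatter is therefore expected, and the estimated step is no change at the digits printed from compound 3 to compound 4 (within the scatter). For compound 4, the estimated dose is 0.1 mg/kg, with an expected range from 0.04 mg/kg to 0.3 mg/kg.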

Compound 4, dose for half-maximal effect: 0.3 mg/kg
Estimate against measurement, compound 4: 3.0-fold (0.48 log units) below; the range from low to high includes it.
By their numbers in this assay, from the lowest: compounds 1, 2 and 3 (each within the scatter of the next); then compound 4.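

In this assay, removing the methyl from the saturated chain carbon bound to a carbonyl carbon and a saturated chain carbon gives a 3.0-fold higher number from compound 3 to compound 4 (0.48 log units; beyond the scatter), so the loss of the methyl registers here, as the earlier exchange of one methyl-bearing chain for the other did not. Hydrogen in place of methyl on a saturated chain carbon bound to an aromatic carbon and a saturated chain carbon gives a 3.0-fold higher number from compound 2 to compound 4 (0.48 log units; beyond the scatter), which means that both methyl-bearing chains sit on the lower side of the unbranched 2-carboxyethyl chain by a modest step. With the 2-carboxyethyl chain held constant, trifluoromethyl in place of the nitrile on an aromatic carbon gives a 3.0-fold higher number from compound 1 to compound 4 (0.48 log units; beyond the scatter), so the choice of this second group also matters with the unbranched chain in place.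

Nothing available explains any of these shifts. As far as these compounds go, it remains open whether an ethyl or a hydroxyl on either chain carbon would behave like the methyl, and whether a nitrile would change the number when paired with a methyl-bearing chain.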